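The source may hold more compounds than are shown below. What is called first, only, known or untested is meant among the compounds shown, and "the series" means these compounds.

Measured compounds:
- Compound 1 `COc1cccc(Oc2ccc(NC(C)=O)cc2)c1` — 4.1 nM
- Compound 2 `CCC(=O)Nc1ccc(Oc2cccc(OC)c2)cc1` — 6.8 nM
- Compound 3 `COc1cccc(Oc2ccc(NC(=O)C3CC3)cc2)c1` — 13 nM

In an assay on isolated protein for binding affinity to melatonin receptor type 1B (Homo sapiens) (a higher number here means a weaker inhibitor, a lower number a stronger inhibitor), compound 3 gives the highest of the three numbers. The nearest is compound 2, the gap being a 1.9-fold higher number from compound 2 to compound 3 (0.28 log units; within the scatter); the furthest is compound 1, with a 3.2-fold higher number from compound 1 to compound 3 (0.50 log units; beyond the scatter), a modest step. The step from the smallest to the next group, a 1.7-fold higher number from compound 1 to compound 2 (0.22 log units; within the scatter), stays within the scatter.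

Compound 4 `C/C=C/C(=O)Nc1ccc(Oc2cccc(OC)c2)cc1` differs from compound 3 by prop-1-en-1-yl in place of cyclopropyl on a carbonyl carbon. Going by the values given here, no measured pair covers this exact exchange. Among the compounds with values here, the steps that bear on it are a 3.2-fold higher number from compound 1 to compound 3 (0.50 log units; beyond the scatter) and a 1.9-fold higher number from compound 2 to compound 3 (0.28 log units; within the scatter), both of which ran toward higher numbers when cyclopropyl entered; for the exchange of cyclopropyl for prop-1-en-1-yl, which keeps the same count of carbon atoms, no direction can be read from them, so no step beyond the scatter is expected in this assay.

Compound 4 is therefore estimated at 12 nM, with a range of 4 nM to 36 nM, corresponding to an expected step of a 1.1-fold lower number from compound 3 to compound 4 (0.03 log units; within the scatter).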

Compound 4, inhibition constant: 2.1 nM
Beside the measured number, compound 4's estimate is 5.7-fold (0.76 log units) above it; the measured number lies below the stated range.
By their numbers in this assay, from the lowest: compounds 4, 1, 2 and 3 (each within the scatter of the next, the first and the last beyond it).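

In this assay, going by these compounds alone, the carbonyl carbon proves sensitive to how the same atoms are joined, not only to how many there are: cyclopropyl and prop-1-en-1-yl are the same in atom count, yet the series shows a 6.2-fold lower number from compound 3 to compound 4 (0.79 log units; beyond the scatter), its largest step so far. Moving beyond methyl therefore need not raise the number, as shown by a 3.2-fold lower number from compound 2 to compound 4 (0.51 log units; beyond the scatter) and by a 2.0-fold lower number from compound 1 to compound 4 (0.29 log units; within the scatter), which leaves those two compounds unseparated. Nothing available gives a reason for the difference between these groups.

A saturated propyl group at this carbonyl carbon would help show whether the double bond or the open chain carries the step. Going by these compounds, how far the position tolerates longer chains, such as a pent-1-en-1-yl group, or a terminal amine also remains open.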